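The compounds below may be only part of what the source reports. "The series", "measured", "known", "first", "only" and "open" are said of these compounds alone.

Measured compounds:
- compound 1 `CC[C@@H]1C(=O)N(C)c2cnc(Nc3ccc(S(=O)(=O)NCCO)cc3)nc2N1C1CCCC1`: 546 nM
- compound 2 `CC[C@@H]1C(=O)N(C)c2cnc(-n3ccc4cc(C(=O)NCC(C)C)ccc43)nc2N1C1CCCC1`: 638 nM
- compound 3 `CCC1C(=O)N(C)c2cnc(-n3ccc4cc(F)ccc43)nc2N1c1ccn(C)n1`: 6070 nM

These three compounds were tested in a functional assay on K562 cells (Homo sapiens) for antiproliferative activity, read by CCK-8 assay, with a stated time of 72 h; a higher number here means a weaker inhibitor of growth, a lower number a stronger inhibitor of growth. Among the three numbers, compound 2 holds the second highest. Compound 1 gives a number so close to that of compound 2 that the two cannot be told apart within the usual scatter. Compound 3 gives a clearly higher number than compound 2, a gap beyond the scatter.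

Compound 4 `CCNC(=O)c1ccc2c(ccn2-c2ncc3c(n2)N(C2CCCC2)[C@H](CC)C(=O)N3C)c1` is not yet measured in this assay. It differs from compound 2 only by methyl in place of isopropyl on a saturated chain carbon bound to an amide-type nitrogen. Among the measured compounds shown here, no measured pair shows this change directly. Since the change is small and sits on the isobutylcarbamoyl tail, the step from compound 2 is expected to stay within the scatter, in either direction: a 1.1-fold higher number from compound 2 to compound 4 (0.04 log units; within the scatter). Compound 4 is therefore estimated at 700 nM, between 300 nM and 1600 nM.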

Compound 4, concentration for 50% growth inhibition: 428 nM
Compound 4: the middle estimate sits 1.6-fold (0.21 log units) above what was measured; the range from low to high includes it.
By their numbers in this assay, from the lowest: compounds 4, 1 and 2 (each within the scatter of the next); then compound 3.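

In this assay, replacing the isobutylcarbamoyl group with ethylcarbamoyl gives a 1.5-fold lower number from compound 2 to compound 4 (0.17 log units; within the scatter) as the step. Among the compounds shown here, this is the first direct reading at this position, and it shows that removing this much of the chain produces no change that can be told apart from the scatter. No measurement here bears on why the two compounds read alike.

Only these two chain lengths are compared at this position. Going by these compounds, it remains open whether a much longer chain, an amine or a carboxylic acid at the end of the chain would give a similar number.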